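A few compounds are considered here, and "the series" means these few. Any claim that something is new, unique, unknown or untested is made for them only; others in the source may bear on it.

Compound 1 `N#Cc1ccc(Nc2nccc(OCc3ccccc3Cl)n2)cc1` is one of three compounds whose toxicity toward the cells has been measured in an ADME assay on MT4 cells (Homo sapiens) for cytotoxicity, read by MTT assay, with a stated time of 5 days; on this read-out lower numbers stand for higher toxicity in this test and higher numbers for lower toxicity in this test. Compound 1 gives 146000 nM, the second highest of the three numbers. Its nearest neighbour is compound 3 `N#Cc1ccc(COc2ccnc(Nc3ccc(C#N)cc3)n2)cc1`, which gives 209000 nM in this assay, with a 1.4-fold higher number from compound 1 to compound 3 (0.16 log units; within the scatter). Furthest from it stands compound 2 `N#Cc1ccc(Nc2nccc(OCc3cccc(C#N)c3)n2)cc1`, which gives 4100 nM in this assay, with a 36-fold lower number from compound 1 to compound 2 (1.55 log units; beyond the scatter). Between those two, a 51-fold higher number from compound 2 to compound 3 (1.71 log units; beyond the scatter).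

Compound 4 `N#Cc1ccc(Nc2nccc(OCc3ccccc3)n2)cc1` has not yet been measured. It differs from compound 1 by hydrogen in place of chloro on an aromatic carbon. The measured steps that bear on this change are the two that replace the 2-chlorophenyl of compound 1: the step to compound 3 stays within the scatter, while the step to compound 2 is large. Losing the chloro without adding a nitrile is a smaller change than either, so no step beyond the scatter is expected for compound 4, with a 1.0-fold higher number from compound 1 to compound 4 (0.01 log units; within the scatter). Compound 4 is therefore estimated at 150000 nM in this assay, in a range from 60000 nM to 400000 nM.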

Compound 4, half-maximal cytotoxic concentration: 13000 nM
Beside the measured number, compound 4's estimate is 12-fold (1.06 log units) above it; the measured number lies below the stated range.
By their numbers in this assay, from the lowest: compound 2; then compound 4; then compounds 1 and 3 (each within the scatter of the next).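

In this assay, the 2-chlorophenyl of compound 1 proves not to be equivalent to an unsubstituted ring, as hydrogen in place of chloro gives a large drop (an 11-fold lower number from compound 1 to compound 4 (1.05 log units; beyond the scatter)), so the closeness of compounds 1 and 3 did not mean that substituents here have little effect. The unsubstituted ring of compound 4 also falls well under the 4-cyanophenyl ring (a 16-fold lower number from compound 3 to compound 4 (1.21 log units; beyond the scatter)) but stands modestly over the 3-cyanophenyl ring (a 3.2-fold higher number from compound 2 to compound 4 (0.50 log units; beyond the scatter)), so groups at this position move the number in both directions from hydrogen. No measurement given here explains these differences.

Chloro appears at only one place on this ring, so the compounds shown leave open whether its step depends on where it sits. They also leave open how a methoxy group or an amine would compare with hydrogen here.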